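A few compounds are considered here, and "the series" means these few. Any claim that something is new, unique, unknown or untested is made for them only; others in the source may bear on it.

Compound 1 `Nc1ccc(S(=O)(=O)N2CCN(c3ncc(C(O)(C(F)(F)F)C(F)(F)F)cc3C3CC3)CC2)cn1` gives 38 mL.min-1.g-1 in an ADME assay (liver) for metabolic stability, with Liver microsome (Homo sapiens) as the target, using microsomes and NADPH, with a stated time of 30 min, tested at 1 uM; on this read-out lower numbers stand for slow clearance and higher numbers for fast clearance.
Compound 2 `Nc1ccc(S(=O)(=O)N2CCN(c3ncc(C(O)(C(F)(F)F)C(F)(F)F)cc3C#CC3CC3)CC2)cn1` returns only a limit in this assay, namely < 14 mL.min-1.g-1.
Compound 3 `Nc1ccc(S(=O)(=O)N2CCN(c3ncc(C(O)(C(F)(F)F)C(F)(F)F)cc3-c3ccncc3)CC2)cn1` gives 15 mL.min-1.g-1 in this assay.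

Among the numbers shown, compound 1 stands highest. Its nearest neighbour is compound 3, and the step of a 2.5-fold lower number from compound 1 to compound 3 (0.40 log units; beyond the scatter). The other value, that of compound 2, is a limit, (the limit of < 14 mL.min-1.g-1 in this assay, at which 1 of the 3 values shown sits), so the step of an at least 2.7-fold lower number from compound 1 to compound 2 (0.43 log units; beyond the scatter) is known only as a floor. Between compound 2 and compound 3 the step of an at least 1.0-fold higher number from compound 2 to compound 3 (0.02 log units; that floor lies within the scatter).

Compound 4 `Nc1ccc(S(=O)(=O)N2CCN(c3ncc(C(O)(C(F)(F)F)C(F)(F)F)cc3-c3cnccc3F)CC2)cn1` differs from compound 1 by the change (4-fluoropyridin-3-yl in place of cyclopropyl on an aromatic carbon). Both measured steps from compound 1 exchange the cyclopropyl on the same aromatic carbon for a larger group, and both lower the number in this assay beyond the scatter. The step to compound 3 is the closer analogy, since compound 4 likewise brings in a six-membered aromatic ring with one hetero atom. A lowering of similar size is therefore expected for compound 4, that is a 2.2-fold lower number from compound 1 to compound 4 (0.35 log units; beyond the scatter). Compound 4 is estimated at 17 mL.min-1.g-1 in this assay, within a range from 10 mL.min-1.g-1 to 30 mL.min-1.g-1, with some chance that only a limit is reported.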

Compound 4, intrinsic clearance in microsomes: 17 mL.min-1.g-1
The estimate for compound 4 equals the measured number at the digits printed; the measured number falls inside the stated range.
By their numbers in this assay, from the lowest: compounds 3 and 4 (each within the scatter of the next); then compound 1. At a limit, below all of these: compound 2.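

In this assay, a second six-membered aromatic ring with 1 hetero atom at this place, ortho to a large group, again lowers the number relative to cyclopropyl: a 2.2-fold lower number from compound 1 to compound 4 (0.35 log units; beyond the scatter). With 4-fluoropyridin-3-yl in place of pyridin-4-yl this read-out shows a 1.1-fold higher number from compound 3 to compound 4 (0.05 log units; within the scatter) and so does not separate the two groups, and neither the added fluorine nor the different point of attachment of the ring shows any effect beyond the scatter. Compound 2 gives only a limit, so an at least 1.2-fold higher number from compound 2 to compound 4 (0.08 log units; that floor lies within the scatter) is known only as a floor: the limit of < 14 mL.min-1.g-1 in this assay, at which 1 of the 4 values shown sits.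

The compounds shown leave open whether the lower numbers depend on the ring nitrogen at all, since a plain phenyl ring would be needed to test that, or on the aromatic ring as such, which a saturated ring such as morpholine would address. They also leave open whether a group smaller than cyclopropyl, such as methyl, or an amine at this place would stand nearer to compound 1 or nearer to compound 4.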